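A Methyl on the Oxetane Ring of Compound 2

The compounds below may be only part of what the source reports. "The series", "measured", "known", "first", "only" and "open" are said of these compounds alone.

Of the compounds shown here, two have so far been measured in an assay on isolated protein for inhibition of retinal dehydrogenase 2 (Homo sapiens); on this read-out higher numbers stand for weaker inhibition and lower numbers for stronger inhibition. Compound 1 `CC(Sc1nc2c(cnn2C)c(=O)n1-c1ccccc1)c1ccccn1` gives 63 nM, and compound 2 `CC(Sc1nc2nn(C3COC3)cc2c(=O)n1-c1ccccc1)c1ccccc1` gives 65 nM. Compound 2 thus stands at the top of the two numbers, yet its gap to compound 1 is within the scatter, so the two values show no real separation. Among the measured compounds shown here, no pair of measured compounds differs in a single place, so no measured step is available for comparison. Compound 3 `CC(Sc1nc2nn(C3(C)COC3)cc2c(=O)n1-c1ccccc1)c1ccccc1` has not yet been measured; it differs from compound 2 in one place: methyl in place of hydrogen on a saturated ring carbon. For the measured compounds named here, a methyl entering for a hydrogen on a saturated ring carbon is a small change, and with no measured step to rest on, the step is expected to amount to a 1.1-fold higher number from compound 2 to compound 3 (0.03 log units; within the scatter), no further than the scatter, in either direction. Compound 3 is therefore estimated to give 70 nM, within a range from 30 nM to 170 nM.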

Compound 3, half-maximal inhibitory concentration: 112 nM
The estimate for compound 3 lay 1.6-fold (0.20 log units) below the measured number; low and high end bracket the measured number.
By their numbers in this assay, from the lowest: compounds 1, 2 and 3 (each within the scatter of the next).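

In this assay, among the compounds shown here, the change from oxetan-3-yl to 3-methyloxetan-3-yl amounts to a 1.7-fold higher number from compound 2 to compound 3 (0.24 log units; within the scatter), the first step that can be read at a single place. It shows that a methyl can take the place of hydrogen on this saturated ring carbon, two ring bonds from the ring oxygen, without carrying the number beyond the usual scatter of the read-out. Nothing available explains the size of this step. On these data alone, whether an ethyl group, a hydroxymethyl group or an amine on the same ring carbon would also stay within the scatter remains open. So does the outcome of replacing the oxetane ring itself, for instance with an azetidine or a cyclobutane ring, since this step concerns only one small group at one position.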